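The compounds below may be only part of what the source reports. "The series", "measured", "known", "first", "only" and "open" are said of these compounds alone.

The three measured compounds share one core and differ only in the amine that sits on an aromatic carbon. Compound 1 `COc1cc(/C=C/c2nc(N(C)C)c3sccc3n2)cc(OC)c1OC` carries a dimethylamino group, compound 2 `COc1cc(/C=C/c2nc(N3CCCC3)c3sccc3n2)cc(OC)c1OC` a pyrrolidin-1-yl group and compound 3 `COc1cc(/C=C/c2nc(N3CCN(C)CC3)c3sccc3n2)cc(OC)c1OC` a 4-methylpiperazin-1-yl group. In a functional assay on L02 cells (Homo sapiens) for inhibition, read by Griess assay, with stated times of 1 h and 24 h (on this read-out higher numbers stand for weaker inhibition and lower numbers for stronger inhibition), compound 2 gives 681000 nM. For compound 1 the same assay reports only a limit, > 1000000 nM. For compound 3 as well only a limit is recorded in this assay, namely > 1000000 nM, so compound 3 stands at the ceiling of what was measured. Two of the three values sit at this ceiling (the limit of > 1000000 nM in this assay, at which 2 of the 3 values shown sit). The measured steps are accordingly small or unreadable: an at least 1.4-fold lower number from compound 1 to compound 2 (0.16 log units; that floor lies within the scatter), an at least 1.4-fold higher number from compound 2 to compound 3 (0.16 log units; that floor lies within the scatter) and a step that the two limits leave unreadable from compound 1 to compound 3.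

Compound 4 `COc1cc(/C=C/c2nc(Nc3ccc(C)cc3)c3sccc3n2)cc(OC)c1OC` brings a further change at the same aromatic carbon: (4-methylphenyl)amino in place of 4-methylpiperazin-1-yl on an aromatic carbon. For the measured compounds named here, none of the measured steps covers an aromatic amine at this position, and the three steps that exist all lie within the scatter or cannot be read. The step from compound 3 is therefore expected to be an at least 1.2-fold lower number from compound 3 to compound 4 (0.09 log units; that floor lies within the scatter), with no direction claimed beyond the scatter. Compound 4 is estimated to give 800000 nM in this assay, between 200000 nM and 3000000 nM, with a real chance that only a limit is reported again.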

Compound 4, half-maximal inhibitory concentration: < 40000 nM
Compound 4 ended at the assay's limit; the forecaster's own chance of this, stated with the estimate: 55%; at least 20-fold (1.30 log units) between middle value and limit.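

Swapping any of the three earlier amines for (4-methylphenyl)amino at this aromatic carbon gives, in this assay, steps beyond the scatter: an at least 25-fold lower number from compound 3 to compound 4 (1.39 log units; beyond the scatter), an at least 17-fold lower number from compound 2 to compound 4 (1.23 log units; beyond the scatter) and an at least 25-fold lower number from compound 1 to compound 4 (1.39 log units; beyond the scatter). The exchanges among dimethylamino, pyrrolidin-1-yl and 4-methylpiperazin-1-yl had shown nothing beyond the scatter or nothing readable, so this position proves to respond to the group placed on it, and the group that enters brings a six-membered aromatic ring of carbon only and a hydrogen-bond donor that 4-methylpiperazin-1-yl lacks. The three sizes are floors rather than measured distances because compound 4 sits at a limit of the assay: the limit of < 40000 nM in this assay, at which 1 of the 4 values shown sits.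

How far compound 4 lies beyond its limit stays open, and the compounds shown do not separate the part played by the aromatic ring from that of the amine hydrogen, a question that a benzylamino group or a methyl(4-methylphenyl)amino group would bear on. Also open, as far as these compounds go, is what the methyl on the aromatic ring contributes, which a plain phenylamino group or a 4-methoxyphenylamino group would address.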